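From Compound 3 to Compound 4: Reading Past a Limit

A few compounds are considered here, and "the series" means these few. Any claim that something is new, unique, unknown or untested is made for them only; others in the source may bear on it.

In an ADME assay on BJ cells (Homo sapiens) for cytotoxicity, with a stated time of 72 h (a lower number here means that less compound is needed, a higher number that more compound is needed for the effect), compound 1 `CCc1ccc(-c2nc3c(c(C)nn3-c3ccccc3)c(-c3ccccc3C#N)c2C#N)cc1` gives > 20000 nM as a limit of the assay and not a number. Compound 2 `CCc1ccc(-c2nc3c(c(C)nn3-c3ccccc3)c(-c3ccccc3OC(F)(F)F)c2C#N)cc1` gives > 20000 nM as a limit too. Compound 3 `CCc1ccc(-c2nc3c(c(C)nn3-c3ccccc3)c(-c3cccc(O)c3)c2C#N)cc1` gives > 20000 nM and this is again only a limit. Compound 3 therefore has no number of its own, and what the series offers so far is the limit of > 20000 nM in this assay, at which 3 of the 3 values shown sit, and not one measured value.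

Compound 4 `CCc1ccc(-c2nc3c(c(C)nn3-c3ccccc3)c(-c3ccccc3C(=O)OC)c2C#N)cc1` carries 2-(methoxycarbonyl)phenyl in place of 3-hydroxyphenyl on an aromatic carbon ortho to a cyano group and opposite the ring nitrogen. Two measured changes bear on this carbon: 3-hydroxyphenyl replaces 2-cyanophenyl in a step that the two limits leave unreadable from compound 1 to compound 3 and replaces 2-(trifluoromethoxy)phenyl in a step that the two limits leave unreadable from compound 2 to compound 3 and neither has a size that can be read. All that these steps support is the expectation that the new group leaves the result where compound 1 and compound 2 already stand. The expected change is a number no higher from compound 3 to compound 4 (the limit leaves the size open) in this assay with no step beyond the scatter and no direction anticipated. Compound 4 is estimated at 20000 nM within an expected range from 10000 nM to 40000 nM and will most likely be reported as a limit once more.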

Compound 4, half-maximal effective concentration: > 20000 nM
Compound 4 gave a limit, no number; the forecaster's own chance of this, stated with the estimate: 90%; the middle value lies on the limit itself.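

No step from compound 1, compound 2 or compound 3 to compound 4 can be read, as all four compounds stand at the same limit: the limit of > 20000 nM in this assay, at which 4 of the 4 values shown sit.

The compounds shown leave open whether the groups on this aromatic carbon differ at all, and at what concentration any of these compounds would reach the half-maximal effect.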